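This account rests on a few compounds, and the source may have more. Where it says the series, first, only, none or still open, it means among the compounds named here.

Working notes on the series. In a functional assay on BCG823 cells (Homo sapiens) for antiproliferative activity, read by MTT assay, with a stated time of 48 h (on this read-out lower numbers stand for stronger inhibition and higher numbers for weaker inhibition), compound 1 `CCN(CC)CCCCOc1c(OC)cc2oc(-c3ccccc3)cc(=O)c2c1O` gives 17400 nM, the lowest of the two numbers in hand. Compound 2 `O=c1cc(-c2ccccc2)oc2cc(O)c(OCCCCN3CCCC3)c(O)c12` gives 86400 nM in this assay, a gap beyond the scatter; both share the core of compound 1 with a basic amine on the side chain. Compound 3 `COc1cc2oc(-c3ccccc3)cc(=O)c2c(O)c1OCCCN1CCN(C)CC1` carries 4-methylpiperazin-1-yl in place of (diethylamino)methyl on a saturated chain carbon, three bonds along the chain from an oxygen on an aromatic ring. Going by the values given here, no measured pair shows this change, so the direction rests on judgement alone. Only a small step is expected, a 1.5-fold lower number from compound 1 to compound 3 (0.16 log units; within the scatter), not clearly beyond the scatter. Compound 3 is estimated at 12000 nM, with a range from 4000 nM to 40000 nM.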

Compound 3, half-maximal inhibitory concentration: 31300 nM
Estimate against measurement, compound 3: 2.6-fold (0.42 log units) below; measured number inside the range.
By their numbers in this assay, from the lowest: compounds 1 and 3 (each within the scatter of the next); then compound 2.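

Going by these compounds alone, the step of a 1.8-fold higher number from compound 1 to compound 3 (0.25 log units; within the scatter) in this assay is the first measured pair for this change: 4-methylpiperazin-1-yl in place of (diethylamino)methyl on a saturated chain carbon leaves compound 3 within the scatter of compound 1. At this position, a ring-bearing amine and an open diethylamino group therefore cannot be told apart in this read-out. No measured evidence bears on this result.

Still open, on these data alone, is how a morpholine or a piperidine would read at this chain end. As far as these compounds go, a longer chain carrying 4-methylpiperazin-1-yl is equally open.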